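The source may report more compounds than this note shows. Statements on the series, on what has been measured and on what is new or still open speak of the compounds shown alone.

Measured so far in a functional assay on aorta for antagonist activity at Alpha-1D adrenergic receptor (Rattus norvegicus); a lower number here means tighter binding, a higher number weaker binding:
compound 1 `COc1ccccc1N1CCN(CCCNc2ncccc2C(=O)C2CC2)CC1` gives 2 nM
compound 2 `CN(C)C(=O)c1cccnc1NCCCN1CCN(c2ccccc2C#N)CC1` gives 10 nM

Compound 2 therefore has the higher of the two dissociation constants, the weaker binding of the pair, and its distance from compound 1 lies beyond the usual scatter. Compound 3 `CN(C)C(=O)c1cccnc1NCCCN1CCN(c2ccccc2OCC(F)(F)F)CC1` keeps the core of compound 2 and changes a single group: 2,2,2-trifluoroethoxy in place of cyano on an aromatic carbon. For the measured compounds named here, no measured pair shows a step of this kind, so the expectation rests on the two values alone. A modest gain in binding is expected, a step of a 2.0-fold lower number from compound 2 to compound 3 (0.30 log units; within the scatter). Compound 3 is expected to give 5 nM, with a likely range from 1.5 nM to 20 nM.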

Compound 3, dissociation constant: 15.9 nM
For compound 3 the middle estimate is 3.2-fold (0.50 log units) below the measured one; the measured number falls inside the stated range.
By their numbers in this assay, from the lowest: compound 1; then compounds 2 and 3 (each within the scatter of the next).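

In this assay the swap of cyano for 2,2,2-trifluoroethoxy gives a 1.6-fold higher number from compound 2 to compound 3 (0.20 log units; within the scatter). This position, on an aromatic carbon and ortho to a large group, therefore accepts a group of 6 heavy atoms in place of one of 2 with no change that can be read. Nothing measured here offers an explanation for this result.

Going by these compounds, whether an amine or a carboxylic acid would be accepted at this position remains open. So does the effect of a small group such as methyl.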